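The source may report more compounds than this note shows. Statements on the series, on what has been measured and on what is new or still open speak of the compounds shown alone.

In a functional assay on DU-145 cells (Homo sapiens) for cytotoxicity, read by trypan blue exclusion, with a stated time of 96 h (a lower number here means a stronger inhibitor, a higher number a weaker inhibitor), compound 1 `COc1cc(OC)c(/C=C/S(=O)(=O)Cc2ccc(OC)c(N)c2)c(OC)c1` gives 4 nM and compound 2 `COC(=O)C(C)(C)Nc1cc(CS(=O)(=O)/C=C/c2c(OC)cc(OC)cc2OC)ccc1OC` gives 2500 nM, the higher of the two numbers. These two compounds differ in one place, with 1-(methoxycarbonyl)-1-methylethyl in place of hydrogen on a nitrogen on an aromatic ring, and the measured change is a 630-fold higher number from compound 1 to compound 2 (2.80 log units; beyond the scatter). Compound 3 `COC(=O)C(Nc1cc(CS(=O)(=O)/C=C/c2c(OC)cc(OC)cc2OC)ccc1OC)c1ccc(Br)cc1` alters that same substituent: (4-bromophenyl)(methoxycarbonyl)methyl in place of 1-(methoxycarbonyl)-1-methylethyl on a nitrogen on an aromatic ring. In words, it has (4-bromophenyl)(methoxycarbonyl)methyl in place of 1-(methoxycarbonyl)-1-methylethyl on a nitrogen on an aromatic ring. The step from compound 1 is the only measured one that bears on this change, and it replaces hydrogen, not one substituent with another, so it does not set the size of the next step directly. Compound 3 still carries a substituent on that nitrogen, so a return to compound 1 at 4 nM is not expected. In this assay, a moderate move to a lower number is expected, with wide uncertainty, as a 3.1-fold lower number from compound 2 to compound 3 (0.49 log units; beyond the scatter). For compound 3 the estimated value is 800 nM, with an expected range from 100 nM to 5000 nM.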

Compound 3, half-maximal inhibitory concentration: 300 nM
For compound 3 the middle estimate is 2.7-fold (0.43 log units) above the measured one, and the stated range covers the measured number.
By their numbers in this assay, from the lowest: compound 1; then compound 3; then compound 2.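

In this assay, the penalty for substituting this nitrogen is not the same for every group: (4-bromophenyl)(methoxycarbonyl)methyl in place of 1-(methoxycarbonyl)-1-methylethyl gives an 8.3-fold lower number from compound 2 to compound 3 (0.92 log units; beyond the scatter), so the number depends on which substituent is present and not only on whether there is one. The recovery is partial, however, as (4-bromophenyl)(methoxycarbonyl)methyl in place of hydrogen on the same nitrogen still gives a 75-fold higher number from compound 1 to compound 3 (1.88 log units; beyond the scatter), and among these three compounds the unsubstituted nitrogen of compound 1 keeps the lowest number. No measurement is available that explains why the exchange of substituents moves the number in this way.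

The bromine and the six-membered aromatic ring enter together in this change, so the compounds shown do not separate their contributions, and they leave open what a plain phenyl in place of the 4-bromophenyl would give. On these data alone, it also remains open how a carboxylic acid in place of the methoxycarbonyl, or a single methyl group on the nitrogen, would compare with compound 1.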